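The source may hold more compounds than are shown below. What is called first, only, known or untested is meant among the compounds shown, and "the series" means these compounds.

Working notes on the series. Compound 1 `COc1cc2cc(Oc3ccc(NC(=O)Nc4ccc(C(F)(F)F)cc4)cc3)c(C)nc2cc1OC` and compound 2 `COc1cc2cc(Oc3ccc(NC(=O)Nc4cccc(C(F)(F)F)c4)cc3)c(C)nc2cc1OC` share one core and differ only in the aryl group on the urea nitrogen. In a functional assay on UACC-62 cells (Homo sapiens) for inhibition, read by sulforhodamine B assay, with a stated time of 48 h, tested at 10 uM (a lower number here means a stronger effect, a higher number a weaker effect of the compound at the concentration tested), compound 1 gives 69.3%, while compound 2 gives 14.5%. Among the measured compounds shown here, the step of a number 54.8 percentage points lower from compound 1 to compound 2 (beyond the scatter) is the only measured step so far. Compound 2 therefore stands lowest of the two numbers, with compound 1 as its nearest neighbour at a clearly higher reading.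

Compound 3 `COc1cc2cc(Oc3ccc(NC(=O)Nc4ccc(Cl)c(C(F)(F)F)c4)cc3)c(C)nc2cc1OC` is the next member and is not yet measured. Compared with compound 2 the change is chloro in place of hydrogen on an aromatic carbon; the new group sits on an aromatic carbon of a six-membered aromatic ring of carbon only, ortho to a trifluoromethyl group.

For the measured compounds named here, no measured step bears directly on this change: the single step from compound 1 to compound 2 concerns the position of the trifluoromethyl group, not the entry of a chloro group, and its size cannot be carried over. With the trifluoromethyl group of compound 2 kept in place, no step beyond the scatter is expected in this assay. For compound 3 the expected result is 15%, with a range from 3% to 40%. The step this implies, a number 0.5 percentage points higher from compound 2 to compound 3 (within the scatter), is an estimate that treats compound 2 as the anchor.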

Compound 3, a percentage reported as activity, at one concentration (the size of the read-out at that concentration, not a potency): -51.5%
Estimate against measurement, compound 3: 66.5 percentage points above; measured number outside the range, below it.
By their numbers in this assay, from the lowest: compound 3; then compound 2; then compound 1.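

In this assay, chloro on the aromatic carbon ortho to a trifluoromethyl group and para to a large group proves far from neutral, with a step of a number 66 percentage points lower from compound 2 to compound 3 (beyond the scatter), and compound 3 gives -51.5%, a reading on the negative side of the scale that neither earlier compound reached. Against compound 1 the step is a number 120.8 percentage points lower from compound 1 to compound 3 (beyond the scatter), so a 4-substituted ring does not by itself go with a weak reading here: the 4-(trifluoromethyl)phenyl group of compound 1 reads high, whereas the 4-chloro-3-(trifluoromethyl)phenyl group of compound 3 reads lowest of the three. No evidence is at hand on what lies behind this step.

The compounds shown leave open whether chloro needs the trifluoromethyl group to give this result, which a 4-chlorophenyl group on the urea nitrogen would address, and whether the position also tolerates a fluoro group, a methoxy group, an amine or a carboxylic acid. All three readings come from a single concentration, so they give the size of the effect at that concentration and not a potency.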